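Replacing a difluorophenyl ketone with a hydroxyphenyl ketone

The source may hold more compounds than are shown below. What is called first, only, known or untested is meant among the compounds shown, and "the series" means these compounds.

Measured compounds:
compound 1 `COc1cc(-c2nnc3n2NC(c2ccco2)C(C(=O)c2ccc(F)c(F)c2)S3)cc(OC)c1OC`: 73200 nM
compound 2 `COc1cc(-c2nnc3n2NC(c2ccco2)C(C(=O)c2ccccc2C)S3)cc(OC)c1OC`: 69900 nM
compound 3 `COc1cc(-c2nnc3n2NC(c2ccco2)C(C(=O)c2ccc(Cl)cc2)S3)cc(OC)c1OC`: > 100000 nM

In a functional assay on MCF7 cells (Homo sapiens) for cytotoxicity, read by MTT assay, with a stated time of 48 h (on this read-out lower numbers stand for stronger inhibition and higher numbers for weaker inhibition), compound 1 gives 73200 nM. Compound 2 sits beside it, since a 1.0-fold lower number from compound 1 to compound 2 (0.02 log units; within the scatter). For compound 3 the value > 100000 nM is a limit of the assay, not a number; accordingly an at least 1.3-fold higher number from compound 1 to compound 3 (0.13 log units; that floor lies within the scatter) and an at least 1.4-fold higher number from compound 2 to compound 3 (0.15 log units; that floor lies within the scatter). Compound 1 therefore stands within the scatter of compound 2, with compound 3 at the limit (the limit of > 100000 nM in this assay, at which 1 of the 3 values shown sits).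

Compound 4 `COc1cc(-c2nnc3n2NC(c2ccco2)C(C(=O)c2ccc(O)cc2)S3)cc(OC)c1OC` differs from compound 1 in one place: 4-hydroxyphenyl in place of 3,4-difluorophenyl on a carbonyl carbon. The measured steps all exchange one aryl group on the carbonyl carbon for another, and none moved beyond the scatter. A similar outcome is expected here, so compound 4 is estimated at 75000 nM, between 30000 nM and 150000 nM, which means an expected 1.0-fold higher number from compound 1 to compound 4 (0.01 log units; within the scatter).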

Compound 4, half-maximal inhibitory concentration: 88900 nM
Beside the measured number, compound 4's estimate is 1.2-fold (0.07 log units) below it, and the stated range covers the measured number.
By their numbers in this assay, from the lowest: compounds 2, 1 and 4 (each within the scatter of the next). At a limit, above all of these: compound 3.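

The 4-hydroxyphenyl group brings a hydrogen-bond donor and acceptor that 3,4-difluorophenyl lacks, yet both steps lie within the scatter: a 1.2-fold higher number from compound 1 to compound 4 (0.08 log units; within the scatter), and a 1.3-fold higher number from compound 2 to compound 4 (0.10 log units; within the scatter). So on this carbonyl carbon, even this exchange leaves the result within the scatter of compounds 1 and 2. Compound 3 gives a limit, not a number: the limit of > 100000 nM in this assay, at which 1 of the 4 values shown sits. The step that joins it to the new value is therefore only a floor: an at least 1.1-fold lower number from compound 3 to compound 4 (0.05 log units; that floor lies within the scatter).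

The compounds shown leave open whether any group here can lift the cytotoxicity beyond the scatter. An amine or a carboxylic acid on this ring might still do so.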